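Removing the Bromo Group from Compound 3

The source may report more compounds than this note shows. Statements on the series, on what has been measured and on what is new or still open speak of the compounds shown alone.

Of the compounds shown here, three sharing one core have been measured in a functional assay on NCI-H1299 cells (Homo sapiens) for inhibition, read by CCK-8 assay, with a stated time of 72 h, tested at 10 uM; a lower number here means less inhibition of growth, a higher number more inhibition of growth at the concentration tested. Compound 1 `CN(C)C(=O)c1cc2cnc(Nc3ccc(NC(=O)C4(C(=O)Nc5cccc(O)c5)CC4)cc3)nc2n1C1CCCC1` gives 78.5%, compound 2 `CN(C)C(=O)c1cc2cnc(Nc3ccc(NC(=O)C4(C(=O)Nc5ccc(Br)cc5)CC4)cc3)nc2n1C1CCCC1` gives 76.9%, and compound 3 `CN(C)C(=O)c1cc2cnc(Nc3ccc(NC(=O)C4(C(=O)Nc5cccc(Br)c5)CC4)cc3)nc2n1C1CCCC1` gives 77.5%. Compound 3 thus lies within the scatter of both others, and the three numbers cannot be ranked.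

The next structure is compound 4 `CN(C)C(=O)c1cc2cnc(Nc3ccc(NC(=O)C4(C(=O)Nc5ccccc5)CC4)cc3)nc2n1C1CCCC1`, which carries hydrogen in place of bromo on an aromatic carbon. Within the data shown here, three measured steps bear on this change, all on the same terminal ring. Bromo in place of hydroxy gave a number 1 percentage points lower from compound 1 to compound 3 (within the scatter). 3-bromophenyl in place of 4-bromophenyl gave a number 0.6 percentage points higher from compound 2 to compound 3 (within the scatter), and 4-bromophenyl in place of 3-hydroxyphenyl gave a number 1.6 percentage points lower from compound 1 to compound 2 (within the scatter). Among the measured compounds shown here, none of these steps leaves the ring without a substituent, so the data offer no direct precedent for phenyl itself. Still, all three substituted rings read alike in this assay, and no step beyond the scatter is expected from this change. The expected size is a number 2.5 percentage points lower from compound 3 to compound 4 (within the scatter). For compound 4 the estimated value is 75%, with an expected range from 65% to 84%.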

Compound 4, percent growth inhibition at one concentration: 90.5%
For compound 4 the middle estimate is 15.5 percentage points below the measured one; measured number outside the range, above it.
By their numbers in this assay, from the lowest: compounds 2, 3 and 1 (each within the scatter of the next); then compound 4.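

In this assay the ring without a substituent is the one that stands apart: hydrogen in place of bromo gives a number 13 percentage points higher from compound 3 to compound 4 (beyond the scatter) and likewise a number 13.6 percentage points higher from compound 2 to compound 4 (beyond the scatter) for the 4-bromophenyl ring, while hydrogen in place of hydroxy gives a number 12 percentage points higher from compound 1 to compound 4 (beyond the scatter) on the 3-hydroxyphenyl ring. The swaps among the substituted rings had all stayed within the scatter, so they gave no sign that this terminal ring could move the number at all, whereas across these four compounds the higher reading goes with the phenyl ring whichever substituent leaves. Nothing available here accounts for the difference between the phenyl ring and its substituted versions.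

As far as these compounds go, whether a fluoro, methyl or methoxy group on this ring would read with compound 4 or with compounds 1, 2 and 3 remains open, and so does whether any group at all on this ring gives the lower reading. All four numbers also come from a single tested concentration, which leaves open how far compound 4 stands apart from the others across a range of concentrations.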